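The compounds below may be only part of what the source reports. "The series", "measured", "known", "first", "only" and "open" are said of these compounds alone.

Three members of the series have been measured. Compound 1 `COc1ccc2c(c1)/C(=C\C(=O)OC(C)(C)C)C(=O)N2` gives 94.2% in a functional assay on HL-60 cells (Homo sapiens) for inhibition, read by CCK-8 assay, with a stated time of 72 h, tested at 20 uM; a higher number here means more inhibition of growth at the concentration tested, a lower number less inhibition of growth. Compound 3 `CC(C)(C)OC(=O)/C=C1/C(=O)Nc2ccc(Cl)cc21` gives 94.9% in this assay. Compound 2 `COc1cccc2c1NC(=O)/C2=C/C(=O)OC(C)(C)C` gives 84.2% in this assay; it is built from the same atoms as compound 1, joined differently, and the difference between the two cores is not broken down here. Against compound 1 the number for compound 2 lies within the scatter; against compound 3 it lies beyond it.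

The change from compound 1 to compound 3 is chloro in place of methoxy on an aromatic carbon. Its size is a number 0.7 percentage points higher from compound 1 to compound 3 (within the scatter), so on this core the exchange left the growth inhibition essentially where it was.

Compound 4 `CC(C)(C)OC(=O)/C=C1/C(=O)Nc2c(Cl)cccc21` is still to be measured in this assay. It differs from compound 2 by chloro in place of methoxy on an aromatic carbon. This is the same kind of change as that from compound 1 to compound 3, but not the same: in the measured pair the carbon bearing the group is meta to a fused ring and para to a fused ring, whereas in compound 2 it is ortho to a fused ring and meta to a fused ring.

Because the matching exchange gave a number 0.7 percentage points higher from compound 1 to compound 3 (within the scatter), the expected step is a number 1.8 percentage points higher from compound 2 to compound 4 (within the scatter). The expectation rests on one pair alone and on a differently placed carbon, so the range is kept wide. Compound 4 is estimated at 86%, between 72% and 95%.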

Compound 4, percent growth inhibition at one concentration: 93.7%
The estimate for compound 4 lay 7.7 percentage points below the measured number; the range from low to high includes it.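

In this assay, chloro in place of methoxy on this second aromatic carbon gives a number 9.5 percentage points higher from compound 2 to compound 4 (within the scatter), so the read-out does not separate the two compounds. Set beside the earlier pair, the step does not differ from the one on the core of compound 1: the same change on two cores in this assay, a number 0.7 percentage points higher (within the scatter) from compound 1 to compound 3 and a number 9.5 percentage points higher (within the scatter) from compound 2 to compound 4, 8.8 percentage points apart, within the scatter of two such steps. In these two pairs the exchange therefore carries from one core to the other without a step beyond the scatter, but two pairs at a single concentration neither show that the steps are equal in size nor establish a rule for other cores or other ring carbons, and they give no measure of potency.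

The compounds shown leave open how an amine or a nitrile in place of chloro or methoxy would read in this assay, and how a carboxylic acid or a longer chain ester would read in place of the tert-butyl ester that all four share. They also leave open whether the exchange would carry over to a core with a methyl group in place of the amide hydrogen.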